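From propanoyl to isobutylcarbonyl in compound 4

The source may report more compounds than this note shows. Statements on the series, on what has been measured and on what is new or still open speak of the compounds shown alone.

In an ADME assay on a cell-free system (plasma, Rattus norvegicus) for metabolic stability, read by LC-MS, with a stated time of 60 min, tested at 100 uM (on this read-out lower numbers stand for a less stable compound and higher numbers for a more stable compound), compound 3 (`CCC(=O)c1ccc(OCCCCOc2ccc(F)c(C(=O)O)c2)c(C)c1O`) gives 96% and lies within the scatter of compound 2 (`Cc1c(OCCCCOc2ccc(C(=O)O)cc2)ccc(C(=O)CC(C)C)c1O`) with 95% and of compound 1 (`Cc1c(OCCCCOc2ccc(C(=O)O)cc2F)ccc(C(=O)CC(C)C)c1O`) with 106% alike. Compound 4 (`Cc1c(OCCCCOc2ccc(F)c(C(=O)O)c2)ccc(C(=O)CC(C)C)c1O`) differs from compound 3 by isopropyl in place of methyl on a saturated chain carbon bound to a carbonyl carbon. For the measured compounds named here, no measured step covers this change. The only one (a number 11 percentage points lower from compound 1 to compound 2 (beyond the scatter)) is hydrogen in place of fluoro on an aromatic carbon, so it bears on this change only indirectly. Compound 1 and compound 2 already carry isobutylcarbonyl, and neither lies beyond the scatter of compound 3. A step no larger than the scatter is therefore expected (a number 3 percentage points higher from compound 3 to compound 4 (within the scatter)). Compound 4 is estimated at 99% (88% to 110%).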

Compound 4, percent of the compound remaining: 101%
Compound 4: middle estimate off by 2 percentage points, on the low side, and the stated range covers the measured number.
By their numbers in this assay, from the lowest: compounds 2, 3, 4 and 1 (each within the scatter of the next, the first and the last beyond it).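

In this assay, the change from propanoyl to isobutylcarbonyl now has a step of its own (a number 5 percentage points higher from compound 3 to compound 4 (within the scatter)), and with 3-carboxy-4-fluorophenyl in place this change stays within the scatter. Both exchanges of the group on the oxygen on a saturated carbon also stay within it (a number 6 percentage points higher from compound 2 to compound 4 (within the scatter); a number 5 percentage points lower from compound 1 to compound 4 (within the scatter)). Nothing available accounts for these steps. As far as these compounds go, whether a longer chain or an amine at this saturated chain carbon would also stay within the scatter remains open. So does whether the propanoyl to isobutylcarbonyl change would read the same with 4-carboxyphenyl or 4-carboxy-2-fluorophenyl on the oxygen.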